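Aryl Exchange on a Shared Glycine Transporter Inhibitor Core

The compounds below may be only part of what the source reports. "The series", "measured", "known", "first", "only" and "open" are said of these compounds alone.

Measured compounds:
compound 1, `CCCS(=O)(=O)N1CCC(CNC(=O)c2ccc(F)cc2C(F)(F)F)(C(=O)N2CCOCC2)CC1`: 67.8 nM
compound 2, `CCCS(=O)(=O)N1CCC(CNC(=O)c2ccccc2OC(F)(F)F)(C(=O)N2CCOCC2)CC1`: 88.4 nM

Of the compounds shown here, two of this shared core have been measured in an assay on isolated protein for inhibition of sodium- and chloride-dependent glycine transporter 1 (Homo sapiens); a higher number here means a weaker inhibitor, a lower number a stronger inhibitor. Compound 2 gives 88.4 nM, the highest of the two numbers; its nearest neighbour is compound 1, with 67.8 nM, and the two lie within the scatter of each other. Compound 3, `CCCS(=O)(=O)N1CCC(CNC(=O)c2c(F)ccc(Cl)c2F)(C(=O)N2CCOCC2)CC1`, has not yet been measured. It differs from compound 2 in one place: 3-chloro-2,6-difluorophenyl in place of 2-(trifluoromethoxy)phenyl on a carbonyl carbon. For the measured compounds named here, the one measured step that bears on this exchange of aryl groups on the carbonyl carbon is a 1.3-fold higher number from compound 1 to compound 2 (0.12 log units; within the scatter), a step that did not exceed the scatter. On that basis compound 3 is expected to move little, giving an expected 1.1-fold lower number from compound 2 to compound 3 (0.04 log units; within the scatter) in this assay, with no direction beyond the scatter claimed. The estimate for compound 3 is 80 nM, with a range from 30 nM to 220 nM.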

Compound 3, half-maximal inhibitory concentration: 8.4 nM
Compound 3: middle estimate off by 9.5-fold (0.98 log units), on the high side, outside the stated range (below it).
By their numbers in this assay, from the lowest: compound 3; then compounds 1 and 2 (each within the scatter of the next).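

In this assay, the aryl group on the carbonyl carbon turns out to be able to shift the number well beyond the scatter, which the earlier pair did not show: 3-chloro-2,6-difluorophenyl gives a large step from the 2-(trifluoromethoxy)phenyl compound (an 11-fold lower number from compound 2 to compound 3 (1.02 log units; beyond the scatter)) and a modest one from the 4-fluoro-2-(trifluoromethyl)phenyl compound (an 8.1-fold lower number from compound 1 to compound 3 (0.91 log units; beyond the scatter)). Compound 3 therefore has the lowest number of the three, with both of its steps beyond the scatter. No measurement shown here accounts for this gain.

The compounds shown leave open whether the chlorine, the two fluorines or their combination carries the gain, as each aryl group differs from the others in more than one substituent. From the compounds shown here alone, it also remains open whether a methyl, a methoxy or a nitrile in place of the chlorine would keep it.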